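The source may hold more compounds than are shown below. What is called first, only, known or untested is meant among the compounds shown, and "the series" means these compounds.

Compound 2 `CO[C@H]1C(=O)N2C(C(=O)C(C)(C)C)=C(C)[C@@H](Sc3nnnn3C)S(=O)(=O)C12` is the reference point for this step. In a physicochemical assay, at pH 7.4 (on this read-out higher numbers stand for a longer-lived compound and lower numbers for a shorter-lived compound), compound 2 gives 18 h, and among the three measured numbers only compound 3 `CO[C@H]1C(=O)N2C(C(=O)c3ccccc3)=C(C)[C@@H](Sc3nnnn3C)S(=O)(=O)C12` stands clearly higher, at 200 h, a gain of an 11-fold higher number from compound 2 to compound 3 (1.05 log units; beyond the scatter) for phenyl in place of tert-butyl on a carbonyl carbon. Compound 1 `CO[C@H]1C(=O)N2C(C(=O)C(C)(C)C)=C(COC(C)=O)CS(=O)(=O)C12` gives 14 h in this assay, a number that lies within the usual scatter of the value for compound 2.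

Compound 4 `CO[C@H]1C(=O)N2C(C(=O)C(C)(C)C)=C(C)[C@@H](OC(C)=O)S(=O)(=O)C12` carries a different change: acetoxy in place of (1-methyl-1H-tetrazol-5-yl)sulfanyl on a saturated ring carbon. Going by the values given here, no measured step touches this saturated ring carbon; the single measured step concerns the carbonyl substituent and leaves the ring unchanged. Compound 1, which carries an acetoxy group on a chain rather than on the ring, differs from compound 2 in more than one place, and its value and that of compound 2 sit within the scatter of each other. Nothing in hand therefore points to a shift beyond the scatter, and the expected step is no change at the digits printed from compound 2 to compound 4 (within the scatter). Compound 4 is estimated at 18 h, with a range from 8 h to 40 h.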

Compound 4, half-life: 6.3 h
Estimate against measurement, compound 4: 2.9-fold (0.46 log units) above; measured number below the stated range.
By their numbers in this assay, from the lowest: compound 4; then compounds 1 and 2 (each within the scatter of the next); then compound 3.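

In this assay, the saturated ring carbon next to the ring sulfur proves not to be a silent position: acetoxy in place of (1-methyl-1H-tetrazol-5-yl)sulfanyl gives a 2.9-fold lower number from compound 2 to compound 4 (0.46 log units; beyond the scatter) and so moves the half-life beyond the scatter. The read-out therefore responds to a change at this ring carbon as well as to the change on the carbonyl carbon, which gives an 11-fold higher number from compound 2 to compound 3 (1.05 log units; beyond the scatter) on the same shared core. No measurement in hand gives a reason for the step at the ring carbon.

From the compounds shown here alone, whether acetoxy has a similar effect when phenyl stands on the carbonyl carbon remains open. Also open, going by these compounds, is how the half-life would respond to an amine, a carboxylic acid or a longer chain on this ring carbon.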